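A few compounds are considered here, and "the series" means these few. Any claim that something is new, unique, unknown or untested is made for them only; others in the source may bear on it.

Compound 1 `CCCc1nc(-c2ccccc2)c(CNCCN2CCN(c3ccc(Cl)cc3)CC2)o1` was tested in an assay on HEK293 cells for inhibition of Voltage-dependent T-type calcium channel subunit alpha-1G (Homo sapiens), read by patch clamp (on this read-out higher numbers stand for weaker inhibition and lower numbers for stronger inhibition), where compound 1 gives 2820 nM. Among the three measured compounds it holds the second highest number. Compound 2 `CCCc1nc(-c2ccccc2)c(CNCCCN2CCN(c3ccccc3Cl)CC2)o1` gives 2800 nM, which sits within the scatter of compound 1. Among the compounds with values here, compound 3 `CCCc1nc(-c2ccccc2)c(CNCCCN2CCN(c3ccc(C(F)(F)F)cc3)CC2)o1` gives 7250 nM, and the only single-site step that was measured, a 2.6-fold higher number from compound 2 to compound 3 (0.41 log units; beyond the scatter), exchanges one aryl group on the ring amine for another. Compound 4 `CCCc1nc(-c2ccccc2)c(CNCCN2CCN(c3ccc(OC)cc3)CC2)o1` differs from compound 1 by methoxy in place of chloro on an aromatic carbon. Within the data shown here, no measured step covers a methoxy group, and the one aryl exchange that was measured moved the number only modestly, so a small step is expected, a 1.2-fold higher number from compound 1 to compound 4 (0.09 log units; within the scatter). Compound 4 is therefore estimated at 3500 nM, within 1500 nM to 9000 nM.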

Compound 4, half-maximal inhibitory concentration: 9200 nM
Estimate against measurement, compound 4: 2.6-fold (0.42 log units) below; the whole stated range lies below it.
By their numbers in this assay, from the lowest: compounds 2 and 1 (each within the scatter of the next); then compounds 3 and 4 (each within the scatter of the next).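

Methoxy in place of chloro on an aromatic carbon, para to a large group, gives a 3.3-fold higher number from compound 1 to compound 4 (0.51 log units; beyond the scatter) in this assay. Within the data shown here, this is the first measured step at this position, and it shows that exchanging this one small group is enough to weaken inhibition beyond the scatter. Nothing available explains this shift.

Still open, on these data alone, is how a hydroxyl, a fluoro or an amine would read at the same position. Also open, as far as these compounds go, is whether methoxy would produce a step of similar size on compounds with a different chain.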